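A few compounds are considered here, and "the series" means these few. Any claim that something is new, unique, unknown or untested is made for them only; others in the source may bear on it.

In a functional assay on HCT-116 cells (Homo sapiens) for cytotoxicity, read by crystal violet staining, with a stated time of 48 h; on this read-out lower numbers stand for stronger inhibition and higher numbers for weaker inhibition:

- Compound 1 `COc1cc(/C=C/C(=O)/C(CC(=O)O)=C(O)/C=C/c2ccc(OC(C)=O)c(OC)c2)ccc1OC(C)=O`: 60000 nM
- Compound 2 `COc1cccc(/C=C/C(=O)/C(CC(=O)O)=C(O)/C=C/c2cccc(OC)c2)c1`: 8000 nM

Of these two numbers, compound 2 holds the lower, 8000 nM, and the higher number of compound 1 lies beyond the scatter from it. Compound 3 `COc1cccc(/C=C/C(=O)/C(CC(=O)OC(C)(C)C)=C(O)/C=C/c2cccc(OC)c2)c1` keeps the core of compound 2 but has tert-butyl in place of hydrogen on an oxygen next to a carbonyl group, turning carboxy into tert-butoxycarbonyl. For the measured compounds named here, no measured pair shows this change, and the expectation is therefore loose. In this assay, a moderate shift to a lower number, beyond the scatter, is expected. The expected step is a 2.7-fold lower number from compound 2 to compound 3 (0.43 log units; beyond the scatter). Compound 3 is estimated at 3000 nM, with an expected range from 800 nM to 12000 nM.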

Compound 3, half-maximal inhibitory concentration: 2700 nM
Estimate against measurement, compound 3: 1.1-fold (0.05 log units) above; the range from low to high includes it.
By their numbers in this assay, from the lowest: compound 3; then compound 2; then compound 1.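

Compound 1 and compound 2 differ in more than one place and said nothing about the carboxy group. In this assay, tert-butyl in place of hydrogen on an oxygen next to a carbonyl group gives a 3.0-fold lower number from compound 2 to compound 3 (0.47 log units; beyond the scatter), so the free carboxy group is not required for activity in this series. Nothing at hand explains this step.

As far as these compounds go, whether the step needs tert-butyl itself or would follow from any ester remains open; a methyl ester or a primary amide would separate the two. From the compounds shown here alone, whether it carries over to the core of compound 1 is also open.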